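Adding a Methyl Group to a Pyrazole Kinase Inhibitor

The compounds below may be only part of what the source reports. "The series", "measured", "known", "first", "only" and "open" are said of these compounds alone.

Compound 1 `c1ccc2c(c1)CC(c1nc3ccc(-c4cn[nH]c4)cc3[nH]1)CO2` is a kinase inhibitor built from a bicyclic ether fused to an imidazole ring that carries a pyrazole at its far end. In an assay on isolated protein for inhibition of Rho-associated protein kinase 2 (Homo sapiens) (a higher number here means a weaker inhibitor, a lower number a stronger inhibitor), compound 1 gives 27 nM. Compound 2 `Nc1nccc(-c2ccc3nc(C4COc5ccccc5C4)oc3c2)n1`, which keeps the same ether part but replaces the pyrazole with an aminopyrimidine on a related core, gives in this assay 27 nM. On these two numbers compound 1 sits level with compound 2, and the two values lie within the scatter of one another.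

Compound 3 `Cc1[nH]ncc1-c1ccc2nc(C3COc4ccccc4C3)[nH]c2c1` differs from compound 1 in a single place: methyl in place of hydrogen on an aromatic carbon. Among the measured compounds shown here, no measured pair shows what such a change does, so the expectation rests on compound 1 alone. A modest weakening beyond the scatter is expected from compound 1 to compound 3, an expected step of a 1.7-fold higher number from compound 1 to compound 3 (0.22 log units; within the scatter), giving for compound 3 an estimated 45 nM, within 14 nM to 140 nM.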

Compound 3, half-maximal inhibitory concentration: 9 nM
Estimate against measurement, compound 3: 5.0-fold (0.70 log units) above; measured number below the stated range.
By their numbers in this assay, from the lowest: compound 3; then compounds 1 and 2 (each within the scatter of the next).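

In this assay, going from 1H-pyrazol-4-yl to 5-methyl-1H-pyrazol-4-yl gives a 3.0-fold lower number from compound 1 to compound 3 (0.48 log units; beyond the scatter) and so makes the inhibitor stronger, not weaker. Among the compounds shown here, this is the first reading of this position: an aromatic carbon next to the ring nitrogen and next to the ring atom that bears a large group, where a single methyl in place of hydrogen gives a gain beyond the scatter. No measurement shown here bears on why the number falls.

On these data alone, whether the gain is particular to methyl remains open, since a longer chain such as ethyl, or an amine or a methoxy group on the same carbon, could keep it, enlarge it or lose it. Also open, as far as these compounds go, is whether the same methyl would help on any core other than that of compound 1.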